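Working notes: cyano to hydroxymethyl on the aryl group

A few compounds are considered here, and "the series" means these few. Any claim that something is new, unique, unknown or untested is made for them only; others in the source may bear on it.

Measured so far:
compound 1 `C[C@@H](O[C@H]1CN2C(=O)C=C(c3ccccc3)CC2[C@@H]1c1ccc(F)cc1)c1cc(C(F)(F)F)cc(C(F)(F)F)c1`: 0.93 nM
compound 2 `C[C@@H](O[C@H]1CN2C(=O)C=C(c3ccc(C#N)cc3)CC2[C@@H]1c1ccc(F)cc1)c1cc(C(F)(F)F)cc(C(F)(F)F)c1`: 1.8 nM

In an assay on CHO cells for displacement of a labelled ligand from Substance-P receptor (Homo sapiens) (a lower number here means a stronger inhibitor, a higher number a weaker inhibitor), compound 1 gives 0.93 nM and compound 2 gives 1.8 nM. Compound 2 has only compound 1 as a measured neighbour; the gap between them is a 1.9-fold higher number from compound 1 to compound 2 (0.29 log units; within the scatter) and lies within the scatter. Compound 3 `C[C@@H](O[C@H]1CN2C(=O)C=C(c3ccc(CO)cc3)CC2[C@@H]1c1ccc(F)cc1)c1cc(C(F)(F)F)cc(C(F)(F)F)c1` is not yet measured; it differs from compound 2 by hydroxymethyl in place of cyano on an aromatic carbon. For the measured compounds named here, the only step touching this position, a 1.9-fold higher number from compound 1 to compound 2 (0.29 log units; within the scatter), did not leave the scatter, so no step beyond the scatter is expected here either. Compound 3 is therefore estimated at 2.5 nM in this assay, with a range from 0.8 nM to 8 nM. That corresponds to an expected step of a 1.4-fold higher number from compound 2 to compound 3 (0.14 log units; within the scatter).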

Compound 3, half-maximal inhibitory concentration: 0.39 nM
Compound 3: the middle estimate sits 6.4-fold (0.81 log units) above what was measured, outside the stated range (below it).
By their numbers in this assay, from the lowest: compound 3; then compounds 1 and 2 (each within the scatter of the next).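

In this assay this position proves responsive to substitution: hydroxymethyl in place of cyano gives a 4.6-fold lower number from compound 2 to compound 3 (0.66 log units; beyond the scatter) and hydroxymethyl in place of hydrogen gives a 2.4-fold lower number from compound 1 to compound 3 (0.38 log units; beyond the scatter), both beyond the scatter, whereas cyano in place of hydrogen stayed within it. Of the three compounds, only compound 3 carries a hydrogen-bond donor on this aryl group, but a single compound cannot tie the step to that donor. Nothing at hand explains the step. The compounds shown leave open whether the hydroxyl itself matters, which methoxymethyl or aminomethyl would test, and whether a longer chain such as hydroxyethyl or a carboxylic acid fits here.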